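A furan-to-phenyl swap and the inhibition expected from it

This account rests on a few compounds, and the source may have more. Where it says the series, first, only, none or still open, it means among the compounds named here.

The two measured compounds are compound 1 `Cc1ccc(-n2nc(-c3ccccc3)nc2CNc2ccc(C(=O)NO)cc2)cc1` and compound 2 `O=C(NO)c1ccc(NCc2nc(-c3ccco3)nn2-c2ccccc2)cc1`. In an assay on Sf9 cells for inhibition of protein deacetylase HDAC6 (Homo sapiens), read by fluorescence, with a stated time of 40 min, tested at 100 nM (on this read-out higher numbers stand for more inhibition at the one concentration tested (going by the name of the read-out) and lower numbers for less inhibition), compound 1 gives 60.7%, and compound 2 gives 59.9%. Compound 2 holds the lowest of the two numbers, yet its nearest neighbour, compound 1, stands within the scatter of it, so the two cannot be told apart on this read-out. Among the measured compounds shown here, no pair of measured compounds differs in a single place, so no measured step exists to lean on.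

Compound 3 `O=C(NO)c1ccc(NCc2nc(-c3ccc(C(F)(F)F)cc3)nn2-c2ccccc2)cc1` differs from compound 2 by 4-(trifluoromethyl)phenyl in place of furan-2-yl on an aromatic carbon. For the measured compounds named here, no measured pair shows what this exchange does in this assay. Since both measured compounds sit in the same range, the step of a number 1.9 percentage points lower from compound 2 to compound 3 (within the scatter) is estimated to be none beyond the scatter. Compound 3 is therefore expected to give about 58%, within a range from 38% to 76%.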

Compound 3, a percentage reported as inhibition, at one concentration (the size of the read-out at that concentration, not a potency): 41.6%
Beside the measured number, compound 3's estimate is 16.4 percentage points above it; measured number inside the range.
By their numbers in this assay, from the lowest: compound 3; then compounds 2 and 1 (each within the scatter of the next).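

In this assay, putting 4-(trifluoromethyl)phenyl in place of furan-2-yl on this aromatic carbon gives a number 18.3 percentage points lower from compound 2 to compound 3 (beyond the scatter), the first step among these compounds that lies beyond the scatter. It shows that this position, on the five-membered aromatic ring with 3 nitrogen, is not indifferent to the group it carries: the entering group, with 10 heavy atoms against 5 and no hydrogen-bond acceptor, comes with less inhibition at the one concentration tested. Nothing measured here bears on why the number falls.

This single exchange alters ring size, the acceptor count and the presence of trifluoromethyl all at once, so the compounds shown do not separate these changes. They also leave open how thiophen-2-yl, or a phenyl ring carrying an amine or a carboxylic acid, would fare on this carbon.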